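Swapping the Phenethyl Cap for a Methylisoxazole

The compounds below may be only part of what the source reports. "The series", "measured", "known", "first", "only" and "open" are said of these compounds alone.

The set holds four peptide-like compounds built on one shared backbone. Compound 1 `Cc1ccc(CNC(=O)[C@H](CCc2ccccc2)NC(=O)[C@H](CNC(=O)CC(C)(C)C)NC(=O)c2cc(C)on2)cc1` and compound 2 `Cc1ccc(CNC(=O)[C@H](CCc2ccccc2)NC(=O)[C@H](CNC(=O)CC(C)(C)C)NC(=O)C(=O)c2c[nH]c3ccccc23)cc1` appear without results: in an assay on HEK293 cells for inhibition of nuclear factor NF-kappa-B complex (Homo sapiens), read by a luciferase reporter, with stated times of 1 h and 3 h (a higher number here means a weaker inhibitor, a lower number a stronger inhibitor), compound 1 stands at "not determined" (no result reported) and compound 2 at "not determined" (no result reported), so neither adds a number. Within the data shown here, compound 3 `CC(C)(C)CNC(=O)C[C@H](NC(=O)CCc1ccccc1)C(=O)N[C@@H](CCc1ccccc1)C(=O)NCc1ccccc1` is thus the only compound with a measurement; in this assay compound 3 gives 12 nM, and with no second measured compound there is no step to set it against.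

Compound 4 `Cc1cc(C(=O)N[C@@H](CC(=O)NCC(C)(C)C)C(=O)N[C@@H](CCc2ccccc2)C(=O)NCc2ccccc2)no1` differs from compound 3 in a single place: 5-methyl-1,2-oxazol-3-yl in place of phenethyl on a carbonyl carbon. Among the measured compounds shown here, no measured pair in the set carries this change, so its size cannot be read from the data, and compound 1, which bears the same (5-methyl-1,2-oxazol-3-yl)carbonyl on a related backbone, lacks a result. On the strength of compound 3 alone, the step is expected to be a modest loss, a 2.5-fold higher number from compound 3 to compound 4 (0.40 log units; beyond the scatter), possibly not beyond the scatter. In this assay compound 4 is expected to give 30 nM, estimated to lie between 6 nM and 150 nM.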

Compound 4, half-maximal inhibitory concentration: 9 nM
For compound 4 the middle estimate is 3.3-fold (0.52 log units) above the measured one; low and high end bracket the measured number.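

Among these compounds, this step is the first comparison the set allows. In this assay, replacing phenethyl with 5-methyl-1,2-oxazol-3-yl on a carbonyl carbon gives a 1.3-fold lower number from compound 3 to compound 4 (0.12 log units; within the scatter), so compound 3 and compound 4 cannot be told apart at this position. The place therefore tolerates a five-membered aromatic ring with 2 hetero atoms and 2 hydrogen-bond acceptors, with 6 heavy atoms in place of 8, and nothing shown here accounts for the two compounds reading alike.

The compounds shown do not separate the contribution of the ring from that of its methyl, so the plain 1,2-oxazol-3-yl remains an open case. Also open, from the compounds shown here alone, is whether a phenyl, a small methyl or a carboxylic acid on the same carbonyl carbon would read the same way.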